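From 4-chlorophenyl to 3-fluorophenyl in a cell assay

A few compounds are considered here, and "the series" means these few. Any claim that something is new, unique, unknown or untested is made for them only; others in the source may bear on it.

Compound 1 `CN1CCN(c2ccc(-c3cc4c(N5CCN(S(=O)(=O)N6CCCCC6)CC5)ncnc4s3)cc2)CC1`: 7570 nM
Compound 2 `CN1CCN(c2ccc(-c3cc4c(N5CCN(C(=O)Nc6ccc(Cl)cc6)CC5)ncnc4s3)cc2)CC1`: 9270 nM

Both values come from a functional assay on MDA-MB-436 cells (Homo sapiens) for antiproliferative activity, read by MTT assay, with a stated time of 48 h; a lower number here means a stronger inhibitor, a higher number a weaker inhibitor. Compound 2 cannot be told apart from compound 1 on these numbers, so neither can be ranked above the other. Compound 3 `CN1CCN(c2ccc(-c3cc4c(N5CCN(C(=O)Nc6cccc(F)c6)CC5)ncnc4s3)cc2)CC1` keeps all of compound 2 except one group, with 3-fluorophenyl in place of 4-chlorophenyl on an amide-type nitrogen. Among the measured compounds shown here, no measured step changes that group alone. The closest evidence is a 1.2-fold higher number from compound 1 to compound 2 (0.09 log units; within the scatter), which came from (4-chlorophenyl)carbamoyl in place of (piperidin-1-yl)sulfonyl on an amine nitrogen in a ring. That wider exchange stayed within the scatter, so a smaller one is expected to do the same, though this rests on a single step. The expected change in this assay is a 1.2-fold lower number from compound 2 to compound 3 (0.06 log units; within the scatter). For compound 3 the estimated value is 8000 nM, with an expected range of 3500 nM to 18000 nM.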

Compound 3, half-maximal inhibitory concentration: 18300 nM
Beside the measured number, compound 3's estimate is 2.3-fold (0.36 log units) below it, and the stated range ends below it.
By their numbers in this assay, from the lowest: compounds 1, 2 and 3 (each within the scatter of the next, the first and the last beyond it).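

The exchange of 4-chlorophenyl for 3-fluorophenyl on the amide-type nitrogen, now seen alone, gives a 2.0-fold higher number from compound 2 to compound 3 (0.30 log units; within the scatter) in this assay, so it cannot be told apart from no change. The wider exchange of (piperidin-1-yl)sulfonyl for (3-fluorophenyl)carbamoyl on the ring nitrogen gives a 2.4-fold higher number from compound 1 to compound 3 (0.38 log units; beyond the scatter), the first step among these compounds to pass beyond the scatter, though only modestly. No measurement shown here accounts for either step.

The halogen and its place on the phenyl ring changed together in one step, so a 4-fluorophenyl or 3-chlorophenyl group would be needed to separate the two. Also open, from the compounds shown here alone, is whether an amine or a carboxylic acid on that ring, or a longer chain in its place, would move the number further.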